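The source may report more compounds than this note shows. Statements on the series, on what has been measured and on what is new or still open speak of the compounds shown alone.

In a functional assay on PC-6 cells (Homo sapiens) for cytotoxicity, read by MTT assay, with a stated time of 3 days (on this read-out lower numbers stand for stronger inhibition and higher numbers for weaker inhibition), compound 1 `CN(C)Cc1ccc(/C=N/Nc2ncnc3sc(C(C)(C)C)cc23)cc1` gives 0.107 ug/mL, and compound 2 `CC(C)(C)c1cc2c(N/N=C/c3ccc(CN)cc3)ncnc2s1` gives 0.214 ug/mL. Compound 3 `COC(=O)c1ccc(/C=N/Nc2ncnc3sc(C(C)(C)C)cc23)cc1` has no number to work from: its entry reads "not determined" (no result reported), so it gives no starting point on this scale. Compound 4 `CN(C)S(=O)(=O)c1ccc(/C=N/Nc2ncnc3sc(C(C)(C)C)cc23)cc1` differs from compound 3 as follows: dimethylsulfamoyl in place of methoxycarbonyl on an aromatic carbon. In words, this is dimethylsulfamoyl in place of methoxycarbonyl on an aromatic carbon, para to a large group.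

Among the measured compounds shown here, only one measured step is available, a 2.0-fold higher number from compound 1 to compound 2 (0.30 log units; within the scatter). It bears on this change only loosely, since it concerns amino in place of dimethylamino on a saturated chain carbon, and neither group of the new pair takes part in it. With no value for compound 3, no size or direction can be assigned to the change itself. The expectation therefore rests on compound 1 at 0.107 ug/mL and compound 2 at 0.214 ug/mL, with a wide margin for the untested group. Compound 4 is expected at about 0.2 ug/mL, with an estimated range from 0.05 ug/mL to 1 ug/mL.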

Compound 4, half-maximal inhibitory concentration: 2.12 ug/mL
Beside the measured number, compound 4's estimate is 11-fold (1.03 log units) below it; measured number outside the range, above it.
By their numbers in this assay, from the lowest: compounds 1 and 2 (each within the scatter of the next); then compound 4.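

In this assay, this place on the six-membered aromatic ring, para to a large group, proves sensitive to the change: dimethylsulfamoyl in place of aminomethyl gives a 9.9-fold higher number from compound 2 to compound 4 (1.00 log units; beyond the scatter) and dimethylsulfamoyl in place of (dimethylamino)methyl gives a 20-fold higher number from compound 1 to compound 4 (1.30 log units; beyond the scatter), whereas the earlier step between the two amine-bearing groups lay within the scatter. Going by these compounds, the step from compound 3 to compound 4 cannot be read, as compound 3 has no number, so how dimethylsulfamoyl compares with methoxycarbonyl remains unknown. Nothing available here accounts for the higher number of compound 4.

On these data alone, it remains open whether the higher number follows from the presence of dimethylsulfamoyl or from the loss of the amine-bearing chain. A carboxylic acid, an unsubstituted sulfamoyl group or a longer aminoalkyl chain at this place could help separate the two.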